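A few compounds are considered here, and "the series" means these few. Any claim that something is new, unique, unknown or untested is made for them only; others in the source may bear on it.

Compound 1 `Cc1ccc(OC2CCN(c3ccc(-n4ccnc4)nn3)CC2)cc1`, in an assay on microsomes from liver for inhibition of acyl-CoA desaturase 1 (Rattus norvegicus); a lower number here means a stronger inhibitor, a higher number a weaker inhibitor: 527 nM
Compound 2 `c1cn(-c2ccc(N3CCC(Oc4ccc5c(c4)CCC5)CC3)nn2)cn1`, in this assay: 62 nM

The two measured compounds share the same core and differ only in the aromatic group attached to the oxygen on a saturated carbon. Among the measured compounds shown here, compound 2 has the lower of the two numbers in this assay, and the single measured step, an 8.5-fold lower number from compound 1 to compound 2 (0.93 log units; beyond the scatter), shows that exchanging the group at this position can shift the number well beyond the scatter. Compound 3 `COc1ccccc1OC1CCN(c2ccc(-n3ccnc3)nn2)CC1` changes the same position again: 2-methoxyphenyl in place of 2,3-dihydro-1H-inden-5-yl on an oxygen on a saturated carbon. Like compound 1, compound 3 carries a plain aromatic ring with a small substituent rather than the fused group of compound 2, so the step is expected to run opposite to the one from compound 1 to compound 2, towards a weaker inhibitor, though its size is uncertain. The step is expected to be a 9.7-fold higher number from compound 2 to compound 3 (0.99 log units; beyond the scatter). Compound 3 is therefore estimated at 600 nM, within a range from 150 nM to 2500 nM.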

Compound 3, half-maximal inhibitory concentration: 543 nM
Beside the measured number, compound 3's estimate is 1.1-fold (0.04 log units) above it; the measured number falls inside the stated range.
By their numbers in this assay, from the lowest: compound 2; then compounds 1 and 3 (each within the scatter of the next).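

In this assay, replacing the 2,3-dihydro-1H-inden-5-yl group with 2-methoxyphenyl gives an 8.8-fold higher number from compound 2 to compound 3 (0.94 log units; beyond the scatter), so a second, different single-ring group also sits well away from compound 2. The two single-ring groups cannot be told apart, with 2-methoxyphenyl in place of 4-methylphenyl giving a 1.0-fold higher number from compound 1 to compound 3 (0.01 log units; within the scatter), so this exchange of methyl for methoxy on the ring leaves the number within the scatter. Among these three compounds, only the group of compound 2, with its added five-membered non-aromatic ring, stands apart, and no available evidence explains this. From the compounds shown here alone, it remains open whether that five-membered ring is itself what matters, since a fused six-membered carbon ring or an unsubstituted phenyl group would be needed for comparison. Going by these compounds, it is also open how an aromatic ring carrying an amine or a carboxylic acid would behave at this place.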